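The source may report more compounds than this note shows. Statements on the series, on what has been measured and on what is new or still open speak of the compounds shown alone.

Among the compounds with values here, the series shares one core, and the three measured members differ only at the amide nitrogen. Compound 1 `COc1ccc2c(=O)c(/C=C/C(=O)NCc3ccccc3)coc2c1` carries a benzyl group there; in a functional assay on L02 cells (Homo sapiens) for inhibition, read by MTT assay, with a stated time of 48 h (a higher number here means a weaker inhibitor, a lower number a stronger inhibitor), compound 1 reaches only a limit of the assay, > 200000 nM. Compound 2 `COc1ccc2c(=O)c(/C=C/C(=O)Nc3cc(C)ccc3C)coc2c1` carries a 2,5-dimethylphenyl; in this assay compound 2 likewise stops at a limit, > 200000 nM. Compound 3 `COc1ccc2c(=O)c(/C=C/C(=O)NCc3ccc(F)cc3F)coc2c1` carries a 2,4-difluorobenzyl; in this assay compound 3 gives a limit as well, > 200000 nM. Because every value sits at the limit of > 200000 nM in this assay, at which 3 of the 3 values shown sit, none of the steps can be sized: a step that the two limits leave unreadable from compound 1 to compound 2, a step that the two limits leave unreadable from compound 1 to compound 3 and a step that the two limits leave unreadable from compound 2 to compound 3 all remain unreadable. Compound 3 therefore stands nowhere in particular on the numbers shown; it is one of three members that are all unresolved at the same limit.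

Compound 4 `CCOc1ccc(NC(=O)/C=C/c2coc3cc(OC)ccc3c2=O)cc1` alters the same position once more: 4-ethoxyphenyl in place of 2,4-difluorobenzyl on an amide-type nitrogen. Within the data shown here, no measured step informs this change, since all three amide substituents already fall outside the measurable window. The expected step is a step that the limit leaves unreadable from compound 3 to compound 4, which means no change beyond the scatter is anticipated. For compound 4 the estimate in this assay is 300000 nM, with a range from 100000 nM to 1000000 nM, most probably reported again only as a limit.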

Compound 4, half-maximal inhibitory concentration: > 200000 nM
Compound 4: only a limit was reported (the forecaster's own chance of this, stated with the estimate: 85%); the middle value is on the limit's open side.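

Compound 4 in this assay gives > 200000 nM, which is a limit of the assay. Its steps from compound 1, compound 2 and compound 3 therefore cannot be read: the limit of > 200000 nM in this assay, at which 4 of the 4 values shown sit.

The compounds shown leave open whether any amide substituent on the shared core gives a measurable half-maximal inhibitory concentration in this assay.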